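A few compounds are considered here, and "the series" means these few. Any claim that something is new, unique, unknown or untested is made for them only; others in the source may bear on it.

Working notes on the series. In a functional assay, with a stated time of 30 min (a higher number here means a weaker inhibitor, a lower number a stronger inhibitor), compound 1 (`O=C(/C=C/c1cc(O)ccc1O)CC(=O)/C=C/c1cccc(O)c1O`) gives 27000 nM and compound 2 (`O=C(/C=C/c1ccccc1O)CC(=O)/C=C/c1cc(O)ccc1O`) gives 48000 nM. Only these two compounds have been measured, so compound 2 stands within the scatter of compound 1 and neither can be ranked.

The next compound is compound 3 (`O=C(/C=C/c1cc(O)ccc1O)CC(=O)/C=C/c1cc(O)ccc1O`), not yet measured. It differs from compound 2 as follows: hydroxy in place of hydrogen on an aromatic carbon. In words, this is hydroxy in place of hydrogen on an aromatic carbon, taking 2-hydroxyphenyl to 2,5-dihydroxyphenyl.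

Among the measured compounds shown here, one measured step bears on this, and it runs the opposite way, with hydrogen in place of hydroxy on an aromatic carbon: a 1.8-fold higher number from compound 1 to compound 2 (0.25 log units; within the scatter). It concerns a hydroxy at another place on the ring, so it is only a rough guide. Since that step stayed within the scatter, no step beyond the scatter is expected in this assay here, and the direction is uncertain, with a slightly lower number favoured.

The estimated change is a 1.6-fold lower number from compound 2 to compound 3 (0.20 log units; within the scatter). For compound 3 the expected value is 30000 nM, with an estimated range of 12000 nM to 70000 nM.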

Compound 3, half-maximal inhibitory concentration: 57000 nM
The estimate for compound 3 lay 1.9-fold (0.28 log units) below the measured number, within the range that was stated.
By their numbers in this assay, from the lowest: compounds 1, 2 and 3 (each within the scatter of the next, the first and the last beyond it).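

In this assay, the hydroxy that takes 2-hydroxyphenyl to 2,5-dihydroxyphenyl gives a 1.2-fold higher number from compound 2 to compound 3 (0.07 log units; within the scatter), so a hydroxy at this place, meta to a large group and para to a hydroxy group, brings no readable change. Among the compounds shown here, exchanging 2,3-dihydroxyphenyl for 2,5-dihydroxyphenyl gives the first step beyond the scatter, a 2.1-fold higher number from compound 1 to compound 3 (0.32 log units; beyond the scatter), which is modest and suggests, on this single pair, that the arrangement of the hydroxy groups on that ring may matter. Compound 2, which lacks the second hydroxy on that ring, stands within the scatter of both compound 1 and compound 3, so it does not fit a simple reading in which that arrangement decides the number.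

No independent data bear on the reason for these differences.

Going by these compounds, it remains open whether a methoxy or a carboxylic acid in place of this hydroxy would give a step beyond the scatter. On these data alone, it is also open whether 2,3-dihydroxyphenyl at both ends of the chain, or an amine on the central chain, would shift the number.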